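The source may report more compounds than this note shows. Statements on the series, on what has been measured and on what is new or still open speak of the compounds shown alone.

Of the compounds shown here, three with a shared core have been measured in a functional assay on SK-BR-3 cells (Homo sapiens) for inhibition; a higher number here means a weaker inhibitor, a lower number a stronger inhibitor. Compound 2 `COc1c(C)cnc(CN2CC(=O)N(C(C)C)c3c(Cl)nc(N)nc32)c1C` gives 20 nM, the lowest of the three numbers. Compound 1 `Cc1cnc(CN2CC(=O)N(CC(C)C)c3c(Cl)nc(N)nc32)c(C)c1Br` gives 60 nM, and compound 3 `Cc1cnc(CN2CC(=O)N(CC(C)C)c3c(Cl)nc(N)nc32)c(C)c1Cl` gives 110 nM. For the measured compounds named here, the only change measured in one place is a 1.8-fold higher number from compound 1 to compound 3 (0.26 log units; within the scatter); it concerns a halogen on an aromatic carbon and so says nothing about the amide-type nitrogen in the ring. Compound 1 and compound 2 differ in more than one place, so their values alone cannot be split into single steps.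

Compound 4 `COc1c(C)cnc(CN2CC(=O)N(CCN3CCCC3)c3c(Cl)nc(N)nc32)c1C` differs from compound 2 by 2-(pyrrolidin-1-yl)ethyl in place of isopropyl on an amide-type nitrogen in a ring. Going by the values given here, no measured step touches that nitrogen, so there is nothing in these data to set a direction; the expectation rests only on the size of the change and on compound 2 as the starting point. Compound 4 is therefore expected to give about 40 nM in this assay, within a range of 10 nM to 160 nM, which means an expected step of a 2.0-fold higher number from compound 2 to compound 4 (0.30 log units; within the scatter).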

Compound 4, half-maximal inhibitory concentration: 300 nM
The estimate for compound 4 lay 7.5-fold (0.88 log units) below the measured number, outside the stated range (above it).
By their numbers in this assay, from the lowest: compound 2; then compounds 1 and 3 (each within the scatter of the next); then compound 4.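

In this assay, replacing isopropyl with 2-(pyrrolidin-1-yl)ethyl on the amide-type nitrogen in the ring gives a 15-fold higher number from compound 2 to compound 4 (1.18 log units; beyond the scatter) and is a large step in the weaker direction. For the compounds shown here, this is the first measured change at this nitrogen, and it shows that the number responds strongly to the group placed there, which the earlier halogen swap on an aromatic carbon could not reveal. Nothing available here explains why the step is this large.

The new group differs from isopropyl in its chain, its ring and its added nitrogen all at once, so these compounds leave open which of those differences goes with the higher number. A plain butyl chain, a 2-methoxyethyl chain or a 2-(dimethylamino)ethyl group on the same nitrogen would help to separate them.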